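Swapping Phenoxy for Dimethylamino in a Cytotoxicity Series

This account rests on a few compounds, and the source may have more. Where it says the series, first, only, none or still open, it means among the compounds named here.

Measured so far, in a functional assay on RXF 393 cells (Homo sapiens) for cytotoxicity, read by sulforhodamine B assay, with a stated time of 48 h, tested at 0.01 uM; a lower number here means a stronger effect, a higher number a weaker effect of the compound at the concentration tested:
- compound 1 `COc1cc(C)cc(-c2nn(CC#N)cc2-c2ccc(-c3cccc(C(C)=O)c3)nc2)c1` gives 89%
- compound 2 `Cc1cc(O)cc(-c2nn(CC#N)cc2-c2ccnc(-c3ccc(Oc4ccccc4)cc3)c2)c1` gives 90%

Both numbers are high, so at this concentration neither compound cuts cell growth by much. Compound 2 holds the higher of the two numbers, but compound 1 sits only a hair lower, a gap that falls within the usual scatter of this assay, so the two cannot be told apart.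

The next compound, compound 3 `Cc1cc(O)cc(-c2nn(CC#N)cc2-c2ccnc(-c3ccc(N(C)C)cc3)c2)c1`, keeps everything of compound 2 except one group: dimethylamino in place of phenoxy on an aromatic carbon. Going by the values given here, the change sits on the outer aromatic ring, and no measured pair in this set shows what such a swap does here. Among the compounds with values here, with only two compounds available, and those two reading alike, there is no basis for expecting a shift beyond the scatter in either direction. Compound 3 is therefore estimated to land close to compound 2, with an expected step of a number 2 percentage points lower from compound 2 to compound 3 (within the scatter) in this assay. The estimate for compound 3 is 88%, with a range from 75% to 100%.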

Compound 3, a percentage reported as activity, at one concentration (the size of the read-out at that concentration, not a potency): 104%
For compound 3 the middle estimate is 16 percentage points below the measured one; measured number outside the range, above it.
By their numbers in this assay, from the lowest: compounds 1 and 2 (each within the scatter of the next); then compound 3.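

In this assay, putting dimethylamino in place of phenoxy on this aromatic carbon, para to a large group, gives a number 14 percentage points higher from compound 2 to compound 3 (beyond the scatter), so the group at this place can move the read-out beyond the scatter, and the move is towards a weaker effect at the concentration tested. The change is not a single feature, however: a group holding a six-membered aromatic ring of carbon only gives way to a smaller one with no ring, and oxygen is exchanged for nitrogen as the atom joined to the outer ring, so this one pair cannot say which of these differences matters. Nothing measured here explains the step.

Still open, as far as these compounds go, is whether the ring or the linking atom accounts for the difference: a methoxy group at this place would keep the oxygen without the ring, while a piperidine ring joined through its nitrogen would keep the nitrogen and bring back a ring. Also open, from the compounds shown here alone, is how these compounds behave at higher concentrations, since a reading at one concentration gives the size of the effect there and not a potency.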